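The source may hold more compounds than are shown below. What is called first, only, known or untested is meant among the compounds shown, and "the series" means these compounds.

Compound 2, with the structure `CC[C@@H](Nc1c(C#N)c(-c2ccc(Br)cc2)nc2cnccc12)C(N)=O`, gives 2.2 in a physicochemical assay for lipophilicity, read by HPLC, at pH 7.5; on this read-out higher numbers stand for higher lipophilicity and lower numbers for lower lipophilicity. Among the three compounds measured it has the highest number, yet its neighbours lie close: compound 3, `CN(CC(N)=O)c1c(C#N)c(-c2ccc(Br)cc2)nc2cnccc12`, gives 2.1, and compound 1, `CC[C@@H](Nc1c(C#N)c(-c2ccc(-c3cccnc3C)cc2)nc2cnccc12)C(N)=O`, gives 1.9, so no ordering can be read from these three.

Compound 4, `CC[C@@H](Nc1c(C#N)c(-c2ccc(-c3cccc(C)c3)cc2)nc2cnccc12)C(N)=O`, is the next compound to be measured. It differs from compound 2 in one place: 3-methylphenyl in place of bromo on an aromatic carbon.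

Going by the values given here, two measured steps touch this comparison. The step at the same aromatic carbon, a number 0.30 log units higher from compound 1 to compound 2 (within the scatter), swapped a ring containing a nitrogen for bromo and moved the number hardly at all. The other step, a number 0.10 log units lower from compound 2 to compound 3 (within the scatter), changed a different part of the molecule and was likewise within the scatter. Neither step puts a six-membered aromatic ring of carbon only in place of bromo, so the measured data give only indirect guidance; the large number of entering carbon atoms counted in the structural change is the main basis for expecting a rise in this assay.

Compound 4 is therefore expected to give about 3.4, within a range from 2.9 to 3.9. That estimate corresponds to an expected step of a number 1.20 log units higher from compound 2 to compound 4 (beyond the scatter), well beyond the scatter.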

Compound 4, distribution coefficient: 3
Estimate against measurement, compound 4: 0.40 log units above; measured number inside the range.
By their numbers in this assay, from the lowest: compounds 1, 3 and 2 (each within the scatter of the next); then compound 4.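

Going by these compounds alone, this position can move the number after all: in this assay, putting 3-methylphenyl in place of bromo gives a number 0.80 log units higher from compound 2 to compound 4 (beyond the scatter), the first step that lies beyond the scatter, whereas the earlier exchange of 2-methylpyridin-3-yl for bromo at the same aromatic carbon stayed within it. Compound 4 also separates two ring-bearing groups that sit at the same place, since replacing 2-methylpyridin-3-yl with 3-methylphenyl gives a number 1.10 log units higher from compound 1 to compound 4 (beyond the scatter), so carrying a ring there does not by itself fix the number, and the identity of the ring matters in this pair. Nothing measured here explains why these two groups differ, so the steps record the size of the change and give no cause.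

As far as these compounds go, it remains open whether 3-methylphenyl would give a similar step on compound 3, which carries (carbamoylmethyl)(methyl)amino in place of (1-carbamoylpropyl)amino. The compounds shown also leave open where the number would fall with an unsubstituted phenyl, a morpholine or a carboxylic acid at this aromatic carbon.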